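Iodo substitution on compound 3 in the 5-hydroxytryptamine receptor 4 series

A few compounds are considered here, and "the series" means these few. Any claim that something is new, unique, unknown or untested is made for them only; others in the source may bear on it.

Measured so far:
compound 1 `CCCCN1CCC(COC(=O)c2ccc(N)c3c2OCCO3)CC1`: 1.4 nM
compound 2 `CCCCN1CCC(COC(=O)c2cc(C#N)c(N)c3c2OCCO3)CC1`: 33 nM
compound 3 `CCCCN1CCC(COC(=O)c2ccc(NC)c3c2OCCO3)CC1`: 9.1 nM

All three numbers come from an assay on HEK293 cells for displacement of a labelled ligand from 5-hydroxytryptamine receptor 4 (Homo sapiens); on this read-out higher numbers stand for weaker inhibition and lower numbers for stronger inhibition. Compound 3 stands second highest of the three; the nearest is compound 2, a step of a 24-fold higher number from compound 1 to compound 2 (1.37 log units; beyond the scatter) away from the lowest value in the set, and the furthest is compound 1, reached by a 6.5-fold higher number from compound 1 to compound 3 (0.81 log units; beyond the scatter) read backwards.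

Compound 4 `CCCCN1CCC(COC(=O)c2cc(I)c(NC)c3c2OCCO3)CC1` has not yet been measured. It differs from compound 3 by iodo in place of hydrogen on an aromatic carbon, at the aromatic carbon ortho to the methylamino group.

Going by the values given here, the step that bears on this change is the one from compound 1 to compound 2, where a cyano group entered at an aromatic carbon of the same core and gave a 24-fold higher number from compound 1 to compound 2 (1.37 log units; beyond the scatter), a large loss. Iodo is a different group, so the size may not carry over, but a substituent at that carbon has so far only weakened inhibition in this assay. A weakening beyond the scatter is therefore expected for compound 4, estimated as a 6.6-fold higher number from compound 3 to compound 4 (0.82 log units; beyond the scatter), giving 60 nM with a range of 15 nM to 250 nM.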

Compound 4, inhibition constant: 7.4 nM
The estimate for compound 4 lay 8.1-fold (0.91 log units) above the measured number; the whole stated range lies above it.
By their numbers in this assay, from the lowest: compound 1; then compounds 4 and 3 (each within the scatter of the next); then compound 2.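

In this assay, iodo in place of hydrogen on the aromatic carbon ortho to the methylamino group gives a 1.2-fold lower number from compound 3 to compound 4 (0.09 log units; within the scatter), so a substituent at this carbon need not weaken inhibition. Going by these compounds alone, the earlier case, cyano on the core of compound 1 with a 24-fold higher number from compound 1 to compound 2 (1.37 log units; beyond the scatter), therefore no longer stands as a rule for the position, and compound 2 is now the one example of weakening there. Nothing available explains why the two substitutions differ.

The two steps start from different compounds, so the shown set leaves open whether the cyano result depends on the group itself or on the hydrogen that compound 3 carries as a methyl on nitrogen. It also leaves open whether chloro, bromo or methoxy at this carbon would stay within the scatter of compound 3.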